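The source may report more compounds than this note shows. Statements on the series, on what has been measured and on what is new or still open speak of the compounds shown alone.

Three compounds of the series carry a reading in an ADME assay on BHK cells (Mesocricetus auratus) for cytotoxicity, read by MTT assay, with a stated time of 96 h; a lower number here means that less compound is tolerated, a higher number that more compound is tolerated. Compound 1 `COc1ccc(-c2nc3cc(C(F)(F)F)ccc3[nH]2)c(OC)c1OC` gives 32000 nM. Compound 2 `Cn1c(-c2ccc(NC(=O)CN3CCCC3)cc2)nc2cc(C(F)(F)F)ccc21` gives 27000 nM, the lower of the two numbers, though the two sit within the scatter of each other. Compound 3 `O=C(O)CCC(=O)Nc1ccc(-c2nc3cc(C(F)(F)F)ccc3[nH]2)cc1` reaches only a limit of the assay, > 100000 nM. That limit, (the limit of > 100000 nM in this assay, at which 1 of the 3 values shown sits), is where one of the three readings sits, and it yields no number for comparison.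

Compound 4 `Cn1c(-c2ccc(N)cc2)nc2cc(C(F)(F)F)ccc21` has not yet been measured in this assay. It is compound 2 with hydrogen in place of ((pyrrolidin-1-yl)methyl)carbonyl on a nitrogen on an aromatic ring. Going by the values given here, no measured pair of the set differs by a change of this kind, so there is no measured step on which to lean. Among the compounds with values here, the one comparison available, compound 1 against compound 2, shows two numbers within the scatter of each other despite different substitution on the shared core, which gives no sign of a large swing in this assay from a change at the periphery. Compound 4 is therefore expected to show a step of a 1.1-fold higher number from compound 2 to compound 4 (0.05 log units; within the scatter) that stays within the scatter, or little beyond it, in either direction. Compound 4 is estimated at 30000 nM, with a range from 10000 nM to 100000 nM.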

Compound 4, half-maximal cytotoxic concentration: 85000 nM
Compound 4: middle estimate off by 2.8-fold (0.45 log units), on the low side; the measured number falls inside the stated range.
By their numbers in this assay, from the lowest: compounds 2 and 1 (each within the scatter of the next); then compound 4. At a limit, above all of these: compound 3.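

In this assay, going by these compounds alone, hydrogen in place of ((pyrrolidin-1-yl)methyl)carbonyl on a nitrogen on an aromatic ring gives a 3.1-fold higher number from compound 2 to compound 4 (0.50 log units; beyond the scatter), the only measured step that isolates a single change. It shows that this place is not silent in the assay: going from the (((pyrrolidin-1-yl)methyl)carbonyl)amino form to the amino form moves the number beyond the scatter, towards more compound tolerated, though one modest step on one pair sets no pattern. Compound 4 now stands close to the top of the readable range, so a further rise from this compound would have little room to show as a number: the limit of > 100000 nM in this assay, at which 1 of the 4 values shown sits.

Which part of the departing group carries the step stays open, and a plain acetyl on the same nitrogen, or a dimethylamino group in place of the pyrrolidine ring, would separate the carbonyl from the ring. Also open, as far as these compounds go, is whether the same step holds on a core without the methyl group that compound 2 and compound 4 share.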